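The compounds below may be only part of what the source reports. "The series", "measured", "known", "first", "only" and "open" are said of these compounds alone.

Of the compounds shown here, three built on one shared core have been tested in a functional assay on HL-60 cells (Homo sapiens) for antiproliferative activity, with a stated time of 24 h; on this read-out lower numbers stand for stronger inhibition and higher numbers for weaker inhibition. Compound 1, `NC(=O)c1c(NC(=O)c2ccccc2Br)sc2c1CCN(C(=S)Nc1ccccc1Br)C2`, gives 17600 nM in this assay. Compound 2, `NC(=O)c1c(NC(=O)c2ccccc2Br)sc2c1CCN(C(=S)Nc1ccccc1C(F)(F)F)C2`, gives 27400 nM in this assay. Compound 3, `NC(=O)c1c(NC(=O)c2ccccc2I)sc2c1CCN(C(=S)Nc1ccccc1Br)C2`, gives 18900 nM in this assay.

Compound 2 differs from compound 1 in a single place: trifluoromethyl in place of bromo on an aromatic carbon The step that accompanies this change is a 1.6-fold higher number from compound 1 to compound 2 (0.19 log units; within the scatter). Compound 3 differs from compound 1 in a different place: iodo in place of bromo on an aromatic carbon The step here is a 1.1-fold higher number from compound 1 to compound 3 (0.03 log units; within the scatter). Between compound 2 and compound 3 no step is computed; their two values simply stand as already given.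

Compound 4, `NC(=O)c1c(NC(=O)c2ccccc2I)sc2c1CCN(C(=S)Nc1ccccc1C(F)(F)F)C2`, has not yet been measured in this assay. It differs from compound 3 as follows: trifluoromethyl in place of bromo on an aromatic carbon This is the same change that leads from compound 1 to compound 2, and it occurs twice among these four compounds. The surroundings of the place are described in identical words in both cases, so the two changes can be called the same. The two cores differ only by iodo in place of bromo on an aromatic carbon, as already described between compound 1 and compound 3.

The step from compound 3 to compound 4 in this assay is expected to be a 1.6-fold higher number from compound 3 to compound 4 (0.20 log units; within the scatter) because the same change gave a 1.6-fold higher number from compound 1 to compound 2 (0.19 log units; within the scatter). Compound 4 is therefore estimated at 30000 nM in this assay, with a range expected from 12000 nM to 75000 nM.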

Compound 4, half-maximal inhibitory concentration: 19700 nM
Compound 4: the middle estimate sits 1.5-fold (0.18 log units) above what was measured, within the range that was stated.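

In this assay, trifluoromethyl in place of bromo on the iodo-bearing core gives a 1.0-fold higher number from compound 3 to compound 4 (0.02 log units; within the scatter), and this step agrees with the one seen earlier on the bromo-bearing core: the same change on two cores in this assay, a 1.6-fold higher number (0.19 log units; within the scatter) from compound 1 to compound 2 and a 1.0-fold higher number (0.02 log units; within the scatter) from compound 3 to compound 4, 1.5-fold (0.17 log units) apart, within the scatter of two such steps Iodo in place of bromo, read on the trifluoromethyl-bearing core, gives a 1.4-fold lower number from compound 2 to compound 4 (0.14 log units; within the scatter), and this step likewise agrees with its earlier counterpart: the same change on two cores in this assay, a 1.1-fold higher number (0.03 log units; within the scatter) from compound 1 to compound 3 and a 1.4-fold lower number (0.14 log units; within the scatter) from compound 2 to compound 4, 1.5-fold (0.17 log units) apart, within the scatter of two such steps Both changes therefore carry from one core to the other without a detectable difference, but every step here lies within the scatter, so the agreement is only between steps too small to read and does not show that a change with a step beyond the scatter would carry over in the same way.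

The compounds shown leave open whether an amine, a carboxylic acid or a longer chain in place of the bromo would give a step beyond the scatter, and whether such a step would hold on both cores. They also leave open whether these four compounds would stay as close together in a read-out other than this assay, which is the only one shown here.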